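The compounds below may be only part of what the source reports. "The series", "measured", "known", "first", "only" and "open" are said of these compounds alone.

Among the compounds with values here, in an assay on HEK293 cells for positive allosteric modulation of metabotropic glutamate receptor 3 (Rattus norvegicus), read by thallium flux, with a stated time of 2.5 min (a lower number here means that less compound is needed, a higher number that more compound is needed for the effect), compound 2 `Cc1c(OCCCCOc2ccc(C(=O)O)cc2F)ccc(C(=O)CC(C)C)c1O` gives 1420 nM, the only number. Compound 1 `Cc1c(OCCCCOc2ccc(C(=O)O)cc2F)ccc(C(=O)CC2CCCC2)c1O` sits at the limit of > 10000 nM in this assay, at which 1 of the 2 values shown sits, so its value of > 10000 nM is a limit and not a number. Within the data shown here, the single measured step, an at least 7.0-fold lower number from compound 1 to compound 2 (0.84 log units; beyond the scatter), changes the group on a saturated chain carbon bound to a carbonyl carbon. Compound 3 `Cc1cc(OCCCCOc2ccc(C(=O)CC(C)C)c(O)c2C)ccc1C(=O)O` differs from compound 2 at another place: 4-carboxy-3-methylphenyl in place of 4-carboxy-2-fluorophenyl on an oxygen on a saturated carbon. Among the measured compounds shown here, no measured step bears on this change, so no shift beyond the scatter is expected for compound 3 in this assay. Compound 3 is estimated at 1500 nM, between 500 nM and 5000 nM. The expected step is a 1.1-fold higher number from compound 2 to compound 3 (0.02 log units; within the scatter).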

Compound 3, half-maximal effective concentration: 3910 nM
The estimate for compound 3 lay 2.6-fold (0.42 log units) below the measured number, within the range that was stated.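

The ether-linked aryl end also matters in this assay: 4-carboxy-3-methylphenyl in place of 4-carboxy-2-fluorophenyl gives a 2.8-fold higher number from compound 2 to compound 3 (0.44 log units; beyond the scatter). Until now, only the group on the saturated chain carbon bound to a carbonyl carbon had been seen to move the number. Nothing on hand bears on the reason for this new step.

Still open, from the compounds shown here alone, is whether the step follows the loss of fluorine or the gain of methyl, which an unsubstituted 4-carboxyphenyl would help to separate. Also open, going by these compounds, is how an amide or a tetrazole would read in place of the carboxylic acid.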